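The compounds below may be only part of what the source reports. "The series", "measured", "known", "first", "only" and "open" are said of these compounds alone.

Compound 1, `COc1cc(-c2cc(/C=C/C(=O)c3ccc(Cl)c(Cl)c3)[nH]n2)cc(OC)c1OC`, is one of two compounds examined in a functional assay on UO-31 cells (Homo sapiens) for cytotoxicity, read by sulforhodamine B assay, with a stated time of 48 h, tested at 10 uM (a higher number here means a weaker effect of the compound at the concentration tested, a lower number a stronger effect), and in that assay compound 1 gives 40%. This is the higher of the two numbers recorded. The other compound, compound 2, `COc1ccc(-c2cc(/C=C/C(=O)c3ccc(N)cc3)[nH]n2)cc1OC`, gives 11% in this assay, a number that lies below compound 1 by more than the usual scatter of such measurements, so compound 2 shows the stronger effect at the tested concentration.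

Compound 3, `COc1ccc(C(=O)/C=C/c2cc(-c3cc(OC)c(OC)c(OC)c3)n[nH]2)cc1OC`, has not yet been measured in this assay. It departs from compound 1 in a single place: 3,4-dimethoxyphenyl in place of 3,4-dichlorophenyl on a carbonyl carbon. For the measured compounds named here, no pair of measured compounds spans this same change, so no measured step guides the expectation. Going by the values given here, both of the compounds measured so far carry methoxy groups on their aryl rings, and compound 2 shows that an aryl group with heteroatom substituents on the carbonyl side can go with a strong effect, though the change there is not the same.

For compound 3 a value near 33% is expected in this assay, with a range from 10% to 60%, so that the expected step is a number 7 percentage points lower from compound 1 to compound 3 (within the scatter), which is estimated to stay within the scatter or only slightly beyond it, in the direction of a somewhat stronger effect.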

Compound 3, a percentage reported as activity, at one concentration (the size of the read-out at that concentration, not a potency): -97%
The estimate for compound 3 lay 130 percentage points above the measured number; the whole stated range lies above it.
By their numbers in this assay, from the lowest: compound 3; then compound 2; then compound 1.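

In this assay, the exchange of 3,4-dichlorophenyl for 3,4-dimethoxyphenyl on a carbonyl carbon gives a number 137 percentage points lower from compound 1 to compound 3 (beyond the scatter), so this single change markedly strengthens the effect at the tested concentration. For the compounds shown here, it is the first measured sign that the group at this place can by itself greatly alter the read-out while the rest of compound 1 stays the same. No measurement at hand explains the step, and this pair cannot say which feature of the entering group matters.

The compounds shown leave open whether both methoxy groups are needed, and whether hydroxyl or ethoxy groups in their place would go with a similar effect. They also leave open whether the same exchange gives a step of similar size on a different core.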